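The source may report more compounds than this note shows. Statements on the series, on what has been measured and on what is new or still open speak of the compounds shown alone.

In a functional assay on DLD-1 cells (Homo sapiens) for inhibition, read by MTT assay, with a stated time of 72 h (on this read-out higher numbers stand for weaker inhibition and lower numbers for stronger inhibition), the compounds measured so far are:
- compound 1 `COc1cc(Oc2cccc(Nc3ccccc3)c2)cc(OC)c1CNCCNC(C)=O`: 6010 nM
- compound 2 `COc1cc(Oc2cccc(Nc3ccccc3)c2)cc(OC)c1CNCc1ccc(Cl)cc1`: 3740 nM

Compound 2, at 3740 nM, stands within the usual scatter of compound 1, so the two cannot be ranked. The next compound, compound 3 `COc1cc(Oc2cccc(Nc3ccccc3)c2)cc(OC)c1CNC(C)C`, carries isopropyl in place of 4-chlorobenzyl on an amine nitrogen.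

Going by the values given here, only one measured step bears on this change, and it falls on the same amine nitrogen: a 1.6-fold lower number from compound 1 to compound 2 (0.21 log units; within the scatter). Exchanging one group there for a very different one therefore left the number within the scatter. One step is thin evidence, so no shift beyond the scatter is expected in this assay, but the range must stay wide. The expected step is a 1.2-fold higher number from compound 2 to compound 3 (0.08 log units; within the scatter). The estimate for compound 3 is 4500 nM, with an expected range of 1800 nM to 11000 nM.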

Compound 3, half-maximal inhibitory concentration: > 20000 nM
Compound 3: no number, only a limit; the forecaster's own chance of this, stated with the estimate: 10%; middle value at least 4.4-fold (0.64 log units) from the limit.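

Two steps on this amine nitrogen now pass beyond the scatter in this assay: an at least 5.3-fold higher number from compound 2 to compound 3 (0.72 log units; beyond the scatter), and an at least 3.3-fold higher number from compound 1 to compound 3 (0.52 log units; beyond the scatter). Isopropyl has no ring, but neither has the 2-acetamidoethyl of compound 1, so the absence of a ring alone does not set compound 3 apart. The reading for compound 3 is a limit of the assay and not a number: the limit of > 20000 nM in this assay, at which 1 of the 3 values shown sits.

As far as these compounds go, the true size of both steps therefore stays open. Also open, from the compounds shown here alone, is whether benzyl without its chlorine, or a longer chain ending in an amine or a carboxylic acid, on this nitrogen would give numbers like those of compound 1 and compound 2 or reach the same limit.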